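The compounds below may be only part of what the source reports. "The series", "measured", "known", "first", "only" and "open" are said of these compounds alone.

Measured compounds:
- compound 1 `COC(=O)c1cc(-c2cccc(NC(=O)c3ccc(/C=C/C(=O)c4cccc(F)c4)cc3)c2)on1` — > 40 ug/mL
- compound 2 `COC(=O)c1cc(-c2cccc(NC(=O)c3ccc(/C=C/C(=O)c4ccccc4)cc3)c2)on1` — > 50 ug/mL
- compound 3 `COC(=O)c1cc(-c2cccc(NC(=O)c3ccc(/C=C/C(=O)c4cccs4)cc3)c2)on1` — "not determined" (no result reported)

In an ADME assay on Vero cells (Chlorocebus sabaeus) for cytotoxicity, read by MTT assay, with a stated time of 72 h (on this read-out lower numbers stand for higher toxicity in this test and higher numbers for lower toxicity in this test), compound 1 gives > 40 ug/mL, which is a limit of the test rather than a number. Compound 2 gives > 50 ug/mL in this assay, again a limit and not a number. For compound 3 the result in this assay is "not determined" (no result reported), so no number stands for it.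

Compound 4 `COC(=O)c1cc(-c2cccc(NC(=O)c3ccc(/C=C/C(=O)c4cc(OC)c(OC)c(OC)c4)cc3)c2)on1` differs from compound 3 by 3,4,5-trimethoxyphenyl in place of thiophen-2-yl on a carbonyl carbon. The only step measured among these compounds is a step that the two limits leave unreadable from compound 1 to compound 2, and because both of its ends are limits (the limit of > 40 ug/mL in this assay, at which 1 of the 3 values shown sits, (the limit of > 50 ug/mL in this assay, at which 1 of the 3 values shown sits)) its size cannot be read. Going by the values given here, no measured step therefore bears directly on the change from compound 3 to compound 4, and no direction beyond the scatter can be predicted. Given that both measured neighbours sit at limits, compound 4 is expected to show 50 ug/mL in this assay, within a range from 20 ug/mL to 100 ug/mL, most likely again reported only as a limit.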

Compound 4, half-maximal cytotoxic concentration: > 50 ug/mL
Compound 4 ended at the assay's limit (the forecaster's own chance of this, stated with the estimate: 70%); the middle value sits exactly at the limit.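

Going by these compounds alone, compound 1, compound 2 and compound 4 all give limits rather than numbers in this assay, and no step among them can be read. The compounds shown leave open the actual concentration at which any of them becomes toxic to the cells, and where compound 3 stands.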